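This account rests on a few compounds, and the source may have more. Where it says the series, first, only, none or still open, it means among the compounds named here.

Measured so far:
- Compound 1 `O=C(NC1CCCCC1)c1cc(Oc2cccc(NC(=S)Nc3ccc(F)c(F)c3)c2)ccn1`: in a functional assay on HCT-116 cells (Homo sapiens) for cytotoxicity, read by MTT assay, with a stated time of 48 h (a higher number here means a weaker inhibitor, a lower number a stronger inhibitor), compound 1 gives 8900 nM
- Compound 2 `O=C(NC1CC1)c1cc(Oc2cccc(NC(=S)Nc3cccc(C(F)(F)F)c3)c2)ccn1`: in this assay compound 2 gives 20200 nM

Compound 2 holds the highest of the two numbers, so it is the weaker of the two inhibitors. Compound 1 sits at a lower number, and the gap between them is beyond the usual scatter of repeated measurements, so the two compounds are genuinely apart. Since compound 1 and compound 2 differ in more than one place, no single change can be held responsible for that gap.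

Compound 3 `O=C(NC1CCCCC1)c1cc(Oc2cccc(NC(=S)Nc3cccc(C(F)(F)F)c3)c2)ccn1` is the next compound and has not yet been measured. It is made from compound 2 by one change: cyclohexyl in place of cyclopropyl on an amide-type nitrogen. The trifluoromethyl-bearing ring stays as it is in compound 2, so the only thing that moves is the ring on the amide-type nitrogen.

For the measured compounds named here, for compound 3 in this assay a modest step toward a lower number is expected, that is a 1.7-fold lower number from compound 2 to compound 3 (0.23 log units; within the scatter), since the only other compound with cyclohexyl on that nitrogen, compound 1, gives the lower number of the two. The estimate for compound 3 is 12000 nM, within a range from 5000 nM to 30000 nM.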

Compound 3, half-maximal inhibitory concentration: 8400 nM
Estimate against measurement, compound 3: 1.4-fold (0.15 log units) above; measured number inside the range.
By their numbers in this assay, from the lowest: compounds 3 and 1 (each within the scatter of the next); then compound 2.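

In this assay, cyclohexyl in place of cyclopropyl on the amide-type nitrogen gives a 2.4-fold lower number from compound 2 to compound 3 (0.38 log units; beyond the scatter), so one change at this position can now be read on its own, and this modest step lies beyond the usual scatter. With cyclohexyl held fixed, 3-(trifluoromethyl)phenyl in place of 3,4-difluorophenyl on an amide-type nitrogen gives a 1.1-fold lower number from compound 1 to compound 3 (0.03 log units; within the scatter), which lies within the scatter, so these two compounds cannot be told apart in this cell test. No measurement at hand accounts for the step from cyclopropyl to cyclohexyl.

The compounds shown place only these two rings on the amide-type nitrogen, so it remains open how a cyclopentyl ring, an open chain such as n-butyl, or a cyclohexyl ring carrying an amine would compare. For the compounds shown here, it is also open whether the change from cyclopropyl to cyclohexyl would give a step of similar size with 3,4-difluorophenyl at the other end of the molecule, since the one step seen here comes with 3-(trifluoromethyl)phenyl in place.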